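This account rests on a few compounds, and the source may have more. Where it says the series, first, only, none or still open, it means among the compounds named here.

Measured in an ADME assay on Vero cells (Chlorocebus sabaeus) for cytotoxicity, read by neutral red uptake, tested at 12.3 ug/mL; a higher number here means a weaker effect of the compound at the concentration tested, a lower number a stronger effect:

Compound 1 `O=C1CSC(c2cccc(Cl)c2)N1CCN1CCCCC1` gives 100%
Compound 2 `O=C1CSC(c2ccc(O)cc2)N1CCN1CCCCC1` gives 100%
Compound 3 `Cc1ccc(C2SCC(=O)N2CCN2CCCCC2)cc1` gives 100%

All three compounds share one core and differ only in the aromatic group attached to a saturated ring carbon. Compound 1 stands level with compounds 2 and 3: the step of no change at the digits printed from compound 1 to compound 2 (within the scatter) and the step of no change at the digits printed from compound 1 to compound 3 (within the scatter) are both flat, as is the step of no change at the digits printed from compound 2 to compound 3 (within the scatter). None of the three groups tried so far, whether bearing chlorine, hydroxy or methyl, has moved the read-out at the concentration tested.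

Compound 4 `O=C1CSC(c2ccccc2Cl)N1CCN1CCCCC1` is the next candidate. It differs from compound 1 in this way: 2-chlorophenyl in place of 3-chlorophenyl on a saturated ring carbon. The chlorine stays, only its place on the aromatic ring moves. For the measured compounds named here, the steps that bear on this change are those from compound 1 to compounds 2 and 3, in which the whole 3-chlorophenyl was exchanged and nothing moved. A smaller rearrangement of the same group is therefore expected to give the step of no change at the digits printed from compound 1 to compound 4 (within the scatter), none beyond the scatter. Compound 4 is expected to give 100%, within 88% to 100%.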

Compound 4, a percentage reported as activity, at one concentration (the size of the read-out at that concentration, not a potency): 100%
Beside the measured number, compound 4's estimate shows no gap at the digits printed; measured number inside the range.
By their numbers in this assay, from the lowest: compounds 1, 2, 3 and 4 (each within the scatter of the next).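

In this assay, shifting the chlorine around the aromatic ring gives no change at the digits printed from compound 1 to compound 4 (within the scatter), so the place of the chlorine on that ring, and not only the choice of group on the saturated ring carbon, has now been tried without any visible effect. Set against the other two groups, 2-chlorophenyl gives no change at the digits printed from compound 3 to compound 4 (within the scatter) and no change at the digits printed from compound 2 to compound 4 (within the scatter), which leaves all four compounds level at the one concentration tested. Nothing available here explains why the read-out stays flat.

Still open, going by these compounds, is whether an amine or a carboxylic acid on the aromatic ring, or a longer chain in place of that ring on the saturated ring carbon, would lower the read-out. A single concentration also leaves open how these four compounds would compare at higher concentrations.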